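A few compounds are considered here, and "the series" means these few. Any claim that something is new, unique, unknown or untested is made for them only; others in the source may bear on it.

Working notes on the series. In a functional assay on the whole organism for inhibition, with Scenedesmus acutus as the target (a higher number here means a weaker inhibitor, a lower number a stronger inhibitor), compound 1 `CCOC(=O)c1cc(N2C(=O)C3=C(CCCC3)C2=O)ccc1Cl` gives 1910 nM, while compound 2 `CCCCCOC(=O)c1cc(N2C(=O)C3=C(CCCC3)C2=O)ccc1Cl` gives 4470 nM, the higher of the two numbers and so the weaker inhibitor of this pair. The next structure is compound 3 `C#CCOc1cc(N2C(=O)C3=C(CCCC3)C2=O)ccc1Cl`, which differs from compound 2 as follows: propargyloxy in place of pentyloxycarbonyl on an aromatic carbon. In words, this is propargyloxy in place of pentyloxycarbonyl on an aromatic carbon, ortho to a chloro group and meta to a large group.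

Among the measured compounds shown here, only one measured step bears on this change: a 2.3-fold higher number from compound 1 to compound 2 (0.37 log units; beyond the scatter). That step is modest and stays within the esters, whereas compound 3 has no ester at all, so it is a loose guide. No ether has been measured in this set. With that single step as the basis, a modest move toward a lower number in this assay is expected, with a real chance of none beyond the scatter. The estimated step is a 3.0-fold lower number from compound 2 to compound 3 (0.47 log units; beyond the scatter). For compound 3 the expected value is 1500 nM, with an estimated range of 300 nM to 6000 nM.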

Compound 3, half-maximal inhibitory concentration: 100 nM
Beside the measured number, compound 3's estimate is 15-fold (1.18 log units) above it, and the stated range ends above it.
By their numbers in this assay, from the lowest: compound 3; then compound 1; then compound 2.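

The position on the aromatic ring, ortho to a chloro group and meta to a large group, responds far more to replacing the ester with an ether than to changing the ester chain: in this assay the chain change gave only a modest step (a 2.3-fold higher number from compound 1 to compound 2 (0.37 log units; beyond the scatter)), whereas propargyloxy in place of pentyloxycarbonyl gives a large one (a 45-fold lower number from compound 2 to compound 3 (1.65 log units; beyond the scatter)). The result does not depend on which ester serves as the reference, since propargyloxy in place of ethoxycarbonyl also gives a large step in the same direction (a 19-fold lower number from compound 1 to compound 3 (1.28 log units; beyond the scatter)), leaving compound 3 as the strongest inhibitor of the three. Nothing available explains why this change has so large an effect.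

The compounds shown do not separate the contribution of the ether oxygen from that of the triple bond, which a propyloxy or allyloxy group at the same position would address, and a propargyl ester would test whether propargyl needs the ether link. From the compounds shown here alone, whether the chloro group is needed alongside propargyloxy also remains open, as a fluoro or bromo group there would show.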